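The compounds below may be only part of what the source reports. "The series", "measured", "known", "first", "only" and "open" are said of these compounds alone.

The three measured compounds share one core, and differ only in the group on one aromatic carbon. Compound 1 `C=CC(=O)Oc1cc(C(F)(F)F)cc(C(F)(F)F)c1` carries a (vinylcarbonyl)oxy group; in an ADME assay for pharmacokinetics, read by LC-MS, in phosphate buffer, with a stated time of 72 h, at pH 7.4, tested at 250 uM (a lower number here means that the compound disappears faster, a higher number that the compound lasts longer), compound 1 gives < 0.017 h, which is a limit of the assay rather than a number. Compound 2 `C=Cc1cc(C(F)(F)F)cc(C(F)(F)F)c1` carries a vinyl group, and in this assay compound 2 gives > 50 h, likewise a limit. Among the measured compounds shown here, compound 3 `C#Cc1cc(C(F)(F)F)cc(C(F)(F)F)c1` carries an ethynyl group, and in this assay compound 3 gives 1.6 h, the only actual number among the three. Compound 3 thus sits between the two limits, with an at least 94-fold higher number from compound 1 to compound 3 (1.97 log units; beyond the scatter) and an at least 31-fold lower number from compound 2 to compound 3 (1.49 log units; beyond the scatter). Compound 4 `FC(F)(F)c1cc(S)cc(C(F)(F)F)c1` differs from compound 3 in one place: sulfanyl in place of ethynyl on an aromatic carbon. For the measured compounds named here, both measured steps that end at compound 3 were large, but neither involved a sulfanyl group, and no measured pair shows how this change acts. For compound 4 the expected step is a 1.3-fold higher number from compound 3 to compound 4 (0.10 log units; within the scatter), which lies within the scatter. Compound 4 is therefore estimated at 2 h, with a range from 0.2 h to 20 h.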

Compound 4, half-life: > 50 h
Compound 4: only a limit was reported; the forecaster's own chance of this, stated with the estimate: 15%; at least 25-fold (1.39 log units) between middle value and limit.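

Replacing ethynyl with sulfanyl gives an at least 31-fold higher number from compound 3 to compound 4 (1.49 log units; beyond the scatter), so on this aromatic carbon a group of one sulfur atom, the first shown here with a hydrogen-bond donor and a hydrogen-bond acceptor, lasts far longer in this assay than ethynyl does. Set against the (vinylcarbonyl)oxy group, the same position gives an at least 2900-fold higher number from compound 1 to compound 4 (3.46 log units; beyond the scatter), so the group on this one carbon spans the whole range of the assay. Compound 4 is reported only as a limit, and the step that links it to compound 2 cannot be read: the limit of > 50 h in this assay, at which 2 of the 4 values shown sit.

Going by these compounds, how long compound 2 and compound 4 really last, and which of them lasts longer, stays open. Also open, on these data alone, is whether a hydroxyl, an amine or a methylsulfanyl group on this carbon would last as long as sulfanyl.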